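The compounds below may be only part of what the source reports. "The series", "measured", "known", "first", "only" and "open" are said of these compounds alone.

Measured compounds:
- compound 1, `CCCCc1cnc(C(C)Cc2ccc(-c3ccccc3C(=O)O)cc2)[nH]1`, gives 184 nM in an in vitro functional assay on cells for agonist activity at Bombesin receptor subtype-3 (Mus musculus), read by luminescence and calcium flux; on this read-out higher numbers stand for an effect only at larger amounts of compound and lower numbers for an effect already at smaller amounts
- compound 2, `O=C(O)c1ccccc1-c1ccc(CCc2ncc(Cc3ccccc3F)[nH]2)cc1`, gives 9.5 nM in this assay
- compound 3, `CCC(C)(C)Cc1c[nH]c(CCc2ccc(-c3ccccc3C(=O)O)cc2)n1`, gives 9.6 nM in this assay

On these three numbers compound 2 stands at the low end. Its number and that of compound 3 lie within the scatter of each other, so no order can be read between them. Compound 1 stands well apart, with a number beyond the scatter of both.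

Compound 4, `O=C(O)c1ccccc1-c1ccc(CCc2ncc(CCC3CCCCC3)[nH]2)cc1`, has not yet been measured. It differs from compound 2 in one place: cyclohexylmethyl in place of 2-fluorophenyl on a saturated chain carbon bound to an aromatic carbon. The shared core, the acid-bearing biaryl and the two-carbon link to the imidazole, all stay as they are.

Compound 3 shows that a saturated branched chain on the imidazole is compatible with a low number in this assay, while compound 1 shows that not every saturated chain is. Going by the values given here, with no measured step for this exact change, a modest shift is expected for compound 4, in the direction of a somewhat larger number, with a 1.6-fold higher number from compound 2 to compound 4 (0.20 log units; within the scatter). Compound 4 is thus estimated at 15 nM, between 4 nM and 60 nM.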

Compound 4, half-maximal effective concentration: 33 nM
Compound 4: middle estimate off by 2.2-fold (0.34 log units), on the low side; low and high end bracket the measured number.
By their numbers in this assay, from the lowest: compounds 2 and 3 (each within the scatter of the next); then compound 4; then compound 1.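

Measured in this assay, putting cyclohexylmethyl in place of 2-fluorophenyl on a saturated chain carbon bound to an aromatic carbon gives a 3.5-fold higher number from compound 2 to compound 4 (0.54 log units; beyond the scatter). Going by these compounds alone, this is the first comparison here between compounds that differ in one place, and it shows that the number responds to this change even though the group that leaves and the group that enters have the same count of heavy atoms. No evidence is at hand on what causes this shift.

The step changes several things at once: the aromatic ring becomes non-aromatic, the fluorine goes and the chain grows longer, so the share of each cannot be separated. Going by these compounds, whether a plain benzyl or a 2-phenylethyl group at this place would give a number closer to that of compound 2 or compound 4 stays open.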